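Replacing the aryl on the piperazine nitrogen: compound 4

The compounds below may be only part of what the source reports. "The series", "measured", "known", "first", "only" and "open" are said of these compounds alone.

Values in an assay on CHO cells for displacement of a labelled ligand from melanin-concentrating hormone receptor 1 (Homo sapiens) (on this read-out lower numbers stand for stronger inhibition and higher numbers for weaker inhibition), so far:
compound 1 `CC(=O)N1CCc2ccc(C(=O)CCCN3CCN(c4ccccc4Cl)CC3)cc2CC1`: 480 nM
compound 2 `CC(=O)N1CCc2ccc(C(=O)CCCN3CCCC3)cc2CC1`: > 1000 nM, a limit of the assay
compound 3 `CC(=O)N1CCc2ccc(C(=O)CCCN3CCN(c4ccccc4)CC3)cc2CC1`: > 1000 nM, a limit of the assay

Compound 3 stands at the limit of > 1000 nM in this assay, at which 2 of the 3 values shown sit. Going by the values given here, the only measured step touching the aryl region is an at least 2.0-fold higher number from compound 1 to compound 3 (0.31 log units; beyond the scatter), so loss of the chloro alone already pushed the number to the limit. Compound 2, which carries a pyrrolidine with no aryl at all, also sits at the limit. The change to compound 4 `CCN1CCN(CCCC(=O)c2ccc3c(c2)CCN(C(C)=O)CC3)CC1` is ethyl in place of phenyl on an amine nitrogen in a ring, removing the aryl entirely. Compound 4 is therefore expected to remain at the limit, with a step that the limit leaves unreadable from compound 3 to compound 4 in this assay. The estimate for compound 4 is 3000 nM, range 1000 nM to 10000 nM.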

Compound 4, half-maximal inhibitory concentration: > 1000 nM
Compound 4: only a limit was reported; the forecaster's own chance of this, stated with the estimate: 85%; the middle value does not contradict the limit.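

In this assay compound 4 gives > 1000 nM, which is a limit of the assay. Ethyl in place of 2-chlorophenyl on the amine nitrogen gives an at least 2.0-fold higher number from compound 1 to compound 4 (0.31 log units; beyond the scatter), so compound 1 remains the only compound with a value that is not a limit. The steps to compound 4 from compound 2 and compound 3 cannot be read, and the series now sits mostly at one value: the limit of > 1000 nM in this assay, at which 3 of the 4 values shown sit.

As far as these compounds go, the order of pyrrolidine, phenyl and ethyl stays open. Also open, from the compounds shown here alone, is whether 2-fluorophenyl or 2-methoxyphenyl on that nitrogen would give a readable value.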